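The compounds below may be only part of what the source reports. "The series", "measured", "known", "first", "only" and "open" are said of these compounds alone.

Of the compounds shown here, three have so far been tested in a functional assay on A549 cells (Homo sapiens) for cytotoxicity, read by fluorescence and resazurin assay, with a stated time of 48 h; a lower number here means a stronger inhibitor, a higher number a weaker inhibitor. Compound 1, `COc1cc(/C=C/c2cc(/C=C/c3cc(OC)c(OC)c(OC)c3)nc(OCCCCBr)n2)cc(OC)c1OC`, reaches only the limit of the assay, returning > 20000 nM, which is a limit rather than a number. Compound 2, `COc1cc(/C=C/c2cc(/C=C/c3cc(OC)c(OC)c(OC)c3)nc(OCCCCCBr)n2)cc(OC)c1OC`, likewise stops at a limit, with > 20000 nM. Compound 3, `BrCCCCCCOc1nc(/C=C/c2ccccc2)cc(/C=C/c2ccccc2)n1`, rests on a different core, and the difference between the two cores is not broken down here. In this assay compound 3 also gives only a limit, > 20000 nM. The change from compound 2 to compound 1 is bromo in place of bromomethyl on a saturated chain carbon, four bonds along the chain from an oxygen on an aromatic ring, and its size, a step that the two limits leave unreadable from compound 2 to compound 1, cannot be read because both values are limits. Among the measured compounds shown here, the only evidence bearing on the measured steps is the limit of > 20000 nM in this assay, at which 3 of the 3 values shown sit.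

Compound 4, `BrCCCCCOc1nc(/C=C/c2ccccc2)cc(/C=C/c2ccccc2)n1`, is not yet measured. It differs from compound 3 by bromo in place of bromomethyl on a saturated chain carbon, five bonds along the chain from an oxygen on an aromatic ring. This is the same kind of change as that from compound 2 to compound 1, though not the same: in the one case the saturated chain carbon lies four bonds along the chain from the oxygen on the aromatic ring, in the other five bonds. The step from compound 3 to compound 4 is expected to be a step that the limit leaves unreadable from compound 3 to compound 4, a step that can only be stated against a limit, because compound 3 itself gives > 20000 nM. Compound 4 is therefore expected to return 30000 nM, with an estimated range from 15000 nM to 80000 nM, most likely reported as a limit again.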

Compound 4, half-maximal inhibitory concentration: > 20000 nM
Compound 4: a limit, no number (the forecaster's own chance of this, stated with the estimate: 85%); the middle value lies beyond the limit too.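

In this assay compound 4 gives > 20000 nM, which is a limit and not a number. Compound 3 also rests on a limit, and no new step can be read between compound 3 and compound 4. The evidence stays as it was: the limit of > 20000 nM in this assay, at which 4 of the 4 values shown sit.

The compounds shown leave open whether any of these chains, on either core, would give a measurable value in this assay.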